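A few compounds are considered here, and "the series" means these few. Any claim that something is new, unique, unknown or untested is made for them only; others in the source may bear on it.

Measured compounds:
- compound 1, `COc1cc(/C=C/C(=O)c2cccc(NC(=O)c3ccco3)c2)ccc1O`: 100% in a functional assay on HUVEC cells (Homo sapiens) for inhibition, tested at 10 ug/mL; on this read-out higher numbers stand for a stronger effect at the one concentration tested and lower numbers for a weaker effect
- compound 2, `CCOC(=O)C(=O)Nc1cccc(C(=O)/C=C/c2ccc(O)c(OC)c2)c1`: in this assay compound 2 gives 66%

Compound 1 stands highest of the two numbers in this assay; its nearest neighbour is compound 2, separated by the step of a number 34 percentage points lower from compound 1 to compound 2 (beyond the scatter). That step is the only one known at the carbonyl carbon of interest, and it exchanges the furan-2-yl for an ethoxycarbonyl, a change of a different kind from the one now considered.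

Compound 3, `COc1cc(/C=C/C(=O)c2cccc(NC(=O)c3cccs3)c2)ccc1O`, differs from compound 1 by thiophen-2-yl in place of furan-2-yl on a carbonyl carbon. Going by the values given here, the only step that bears on it is a number 34 percentage points lower from compound 1 to compound 2 (beyond the scatter), which shows that a change at this carbonyl carbon can move this assay well beyond the scatter; the swap to thiophen-2-yl keeps the ring of the same size and count, so a smaller step is expected here, at most a modest drop and possibly none beyond the scatter. For compound 3 the expected result in this assay is 90% (range 70% to 100%), which corresponds to an expected step of a number 10 percentage points lower from compound 1 to compound 3 (within the scatter).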

Compound 3, a percentage reported as inhibition, at one concentration (the size of the read-out at that concentration, not a potency): 90%
Beside the measured number, compound 3's estimate shows no gap at the digits printed; the range from low to high includes it.
By their numbers in this assay, from the lowest: compound 2; then compounds 3 and 1 (each within the scatter of the next).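

At the carbonyl carbon bonded to the amide-type nitrogen, exchanging furan-2-yl for thiophen-2-yl gives no change that can be separated from the scatter in this assay, with a number 10 percentage points lower from compound 1 to compound 3 (within the scatter). The thiophen-2-yl group also stands clear of the ethoxycarbonyl group in this assay, with a number 24 percentage points higher from compound 2 to compound 3 (beyond the scatter), so this read-out tolerates oxygen or sulfur as the hetero atom in the five-membered aromatic ring. No measurement at hand accounts for either step.

Still open, from the compounds shown here alone, is whether an aromatic ring is needed here at all, which a saturated tetrahydrofuran-2-yl ring, a phenyl ring or a short alkyl chain on the same carbonyl carbon would address. A read-out at one concentration gives no potency, so any difference between the furan-2-yl and thiophen-2-yl compounds remains unresolved.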